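Halogen change on the aryl group of compound 3

The source may hold more compounds than are shown below. What is called first, only, known or untested is meant among the compounds shown, and "the series" means these compounds.

Values in a functional assay on MCF7 cells (Homo sapiens) for inhibition, read by MTT assay, with a stated time of 48 h, tested at 10 uM (on this read-out higher numbers stand for more inhibition of growth at the one concentration tested and lower numbers for less inhibition of growth), so far:
- compound 1 `Cc1cc(=O)c2c(O)cc(OCc3ccccc3)c([C@H]3CCN(C)C[C@H]3O)c2o1` gives 1%
- compound 2 `Cc1cc(=O)c2c(O)c(CN3CC(O)CC3C(=O)O)c(O)c([C@H]3CCN(C)C[C@H]3O)c2o1` gives 25%
- compound 3 `Cc1oc2c([C@H]3CCN(C)C[C@H]3O)c(O)cc(O)c2c(=O)c1C(O)c1ccc(Cl)cc1` gives 6%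

Compound 3 lies within the scatter of compound 1 and beyond the scatter under compound 2. Compound 4 `Cc1oc2c([C@H]3CCN(C)C[C@H]3O)c(O)cc(O)c2c(=O)c1C(O)c1ccc(F)c(Br)c1` has 3-bromo-4-fluorophenyl in place of 4-chlorophenyl on a saturated chain carbon bound to an aromatic carbon and an oxygen on a saturated carbon. Among the measured compounds shown here, no measured pair isolates a change of this kind, so its size cannot be read directly. The a number 2 percentage points higher from compound 3 to compound 4 (within the scatter) expected in this assay is small and stays within the scatter, without a firm direction. Compound 4 is estimated at 8% within a range of 0% to 20% for this read-out.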

Compound 4, percent growth inhibition at one concentration: 14%
Beside the measured number, compound 4's estimate is 6 percentage points below it; the measured number falls inside the stated range.
By their numbers in this assay, from the lowest: compounds 1, 3 and 4 (each within the scatter of the next, the first and the last beyond it); then compound 2.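

In this assay, among the compounds shown here, the exchange of 4-chlorophenyl for 3-bromo-4-fluorophenyl on the saturated chain carbon gives a number 8 percentage points higher from compound 3 to compound 4 (within the scatter) and is the first one-place step. The position thus carries this larger dihalogenated aryl group, and the two compounds stay level within the scatter. No available evidence bears on the reason for this result. The two compounds leave the separate contributions of bromine and fluorine unresolved. Also open, on these data alone, is whether an amine or a carboxylic acid in place of the aryl group would shift growth inhibition beyond the scatter.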